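The source may report more compounds than this note shows. Statements on the series, on what has been measured and on what is new or still open speak of the compounds shown alone.

Compound 1 `CC1(C)Oc2ccc(C#N)cc2[C@@H](/N=C(\NC#N)Nc2ccc(Cl)cc2)[C@@H]1O` gives 1800 nM
Compound 2 `CC(=O)c1ccc(N/C(=N/[C@@H]2c3cc(C#N)ccc3OC(C)(C)[C@H]2O)NC#N)cc1` gives 21000 nM
Compound 3 `CC1(C)Oc2ccc(C#N)cc2[C@@H](/N=C(\NC#N)Nc2ccc(C(=O)O)cc2)[C@@H]1O` gives > 100000 nM (a limit)

In a functional assay (aorta) with Rattus norvegicus as the target (on this read-out higher numbers stand for weaker inhibition and lower numbers for stronger inhibition), compound 3 gives > 100000 nM, which is a limit and not a number. Compound 3 has the highest reading of the three, and so the weakest inhibition. Compound 4 `COc1ccc(N/C(=N/[C@@H]2c3cc(C#N)ccc3OC(C)(C)[C@H]2O)NC#N)cc1` differs from it in one place: methoxy in place of carboxy on an aromatic carbon, with methoxy in place of carboxy on an aromatic carbon, para to a large group.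

Three measured steps at this same place bear on the change. Carboxy in place of chloro gave an at least 55-fold higher number from compound 1 to compound 3 (1.74 log units; beyond the scatter), hydroxy in place of methyl on a carbonyl carbon gave an at least 4.7-fold higher number from compound 2 to compound 3 (0.67 log units; beyond the scatter), and acetyl in place of chloro gave a 12-fold higher number from compound 1 to compound 2 (1.07 log units; beyond the scatter). Among the compounds with values here, all three lie beyond the scatter, and no compound measured so far carries methoxy. Both compounds without the carboxy read lower than compound 3, so a large move is expected in the same direction when it is removed. The expected change is an at least 16-fold lower number from compound 3 to compound 4 (1.22 log units; beyond the scatter), towards a lower number and stronger inhibition.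

For compound 4 the estimate is 6000 nM, with an expected range from 1500 nM to 25000 nM.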

Compound 4, half-maximal inhibitory concentration: 32500 nM
For compound 4 the middle estimate is 5.4-fold (0.73 log units) below the measured one; measured number above the stated range.
By their numbers in this assay, from the lowest: compound 1; then compounds 2 and 4 (each within the scatter of the next). At a limit, above all of these: compound 3.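

Methoxy in place of carboxy gave an at least 3.0-fold lower number from compound 3 to compound 4 (0.48 log units; beyond the scatter) in this assay, so losing the carboxy does not by itself bring the reading back to that of compound 1. On these data alone, the size of that step stays open, because compound 3 is recorded only as a limit: the limit of > 100000 nM in this assay, at which 1 of the 4 values shown sits. Methoxy and acetyl are not told apart at this position, with a 1.5-fold higher number from compound 2 to compound 4 (0.19 log units; within the scatter), whereas methoxy in place of chloro gave an 18-fold higher number from compound 1 to compound 4 (1.26 log units; beyond the scatter), which leaves chloro alone with the lowest number among the four groups.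

The compounds shown leave open whether bromo, fluoro or methyl at this position would read like chloro, or like methoxy and acetyl. They also leave open whether plain hydrogen here would fall with either pair.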